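This account rests on a few compounds, and the source may have more. Where it says the series, first, only, none or still open, it means among the compounds named here.

In a functional assay on PC-3M cells (Homo sapiens) for cytotoxicity, read by MTT assay, with a stated time of 48 h (a lower number here means a stronger inhibitor, a higher number a weaker inhibitor), three closely related compounds have been measured so far, and none of them returned a number. Compound 1 `CCCc1nnc(SCc2ccccc2)n1N1C(=O)c2ccccc2C1=O` carries a benzylsulfanyl group, and in this assay compound 1 gives > 200000 nM, which is a limit rather than a number. Compound 2 `CCCc1nnc(SC)n1N1C(=O)c2ccccc2C1=O` is its methylsulfanyl counterpart, and compound 2 gives > 200000 nM, again a limit. Compound 3 `COc1cc(-c2nnc(SC)n2N2C(=O)c3ccccc3C2=O)cc(OC)c1OC` rests on a different core; the difference between the two cores is not broken down here. In this assay compound 3 gives > 200000 nM, once more a limit. The step that the two limits leave unreadable from compound 2 to compound 1 cannot be read because of the limit of > 200000 nM in this assay, at which 3 of the 3 values shown sit. The change from compound 2 to compound 1 is phenyl in place of hydrogen on a saturated chain carbon bound to a sulfur, and the same change, (phenyl in place of hydrogen on a saturated chain carbon bound to a sulfur), leads from compound 3 to the unmeasured compound 4 `COc1cc(-c2nnc(SCc3ccccc3)n2N2C(=O)c3ccccc3C2=O)cc(OC)c1OC`. Because (the limit of > 200000 nM in this assay, at which 3 of the 3 values shown sit), compound 4 is expected to behave like the three measured compounds. The step that this change is estimated to make is a number no higher from compound 3 to compound 4 (the limit leaves the size open), resting on the unreadable step of the same change. Compound 4 is therefore estimated at 200000 nM, most probably reported as a limit once again.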

Compound 4, half-maximal inhibitory concentration: > 200000 nM
Compound 4 was reported as a limit; the forecaster's own chance of this, stated with the estimate: 85%; the middle value lies on the limit itself.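

Compound 4 adds no readable step in this assay, neither from compound 3 nor from compound 1, because the values on both sides of each step are limits: the limit of > 200000 nM in this assay, at which 4 of the 4 values shown sit. The compounds shown leave open whether the change from methylsulfanyl to benzylsulfanyl, or that from propyl to 3,4,5-trimethoxyphenyl, alters the result in this assay at all.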